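The source may hold more compounds than are shown below. What is called first, only, known or untested is meant among the compounds shown, and "the series" means these compounds.

Measured compounds:

Compound 1 `Cc1nc(N)sc1CCCN/C(N)=N/C(=O)NC(C)c1ccc(Br)cc1`: 30.2 nM
Compound 2 `Cc1nc(N)sc1CCCN/C(N)=N/C(=O)NC(C)c1ccc(Cl)cc1`: 46.8 nM
Compound 3 `Cc1nc(N)sc1CCCN/C(N)=N/C(=O)NC(C)c1cccs1`: 63.1 nM

All three were tested in an assay on membranes from Sf9 cells for displacement of a labelled ligand from histamine H2 receptor (Homo sapiens), read by scintillation counting, with a stated time of 60 min; on this read-out higher numbers stand for weaker inhibition and lower numbers for stronger inhibition. Among them compound 3 gives the highest number, with 63.1 nM; its nearest neighbour is compound 2, and the gap to compound 1 is described by a 2.1-fold higher number from compound 1 to compound 3 (0.32 log units; beyond the scatter).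

Compound 4 `Cc1nc(N)sc1CCCN/C(N)=N/C(=O)NC(C)c1ccco1` has not yet been measured. It differs from compound 3 in one place: furan-2-yl in place of thiophen-2-yl on a saturated chain carbon bound to an amide-type nitrogen and a saturated chain carbon. This is a swap of one five-membered aromatic ring for another of the same size.

The measured steps that come closest to this change are a 2.1-fold higher number from compound 1 to compound 3 (0.32 log units; beyond the scatter) and a 1.3-fold higher number from compound 2 to compound 3 (0.13 log units; within the scatter), both of which exchange a six-membered aromatic ring bearing a halogen for the thiophen-2-yl group and both of which raise the number only modestly or stay within the scatter. The furan-2-yl exchange is even smaller in kind, so in this assay no step beyond the scatter is expected. The expected step is at most a slight rise, a 1.3-fold higher number from compound 3 to compound 4 (0.10 log units; within the scatter). Compound 4 is therefore estimated at 80 nM, with a range from 35 nM to 180 nM.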

Compound 4, inhibition constant: 31.6 nM
Compound 4: middle estimate off by 2.5-fold (0.40 log units), on the high side; the measured number lies below the stated range.
By their numbers in this assay, from the lowest: compounds 1, 4, 2 and 3 (each within the scatter of the next, the first and the last beyond it).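

In this assay, replacing the ring sulfur of thiophen-2-yl with the oxygen of furan-2-yl gives a 2.0-fold lower number from compound 3 to compound 4 (0.30 log units; within the scatter), so this exchange of one five-membered ring for another cannot be told apart from repeat-measurement noise. The furan-2-yl group also stays within the scatter of both halogen-bearing groups, with a 1.5-fold lower number from compound 2 to compound 4 (0.17 log units; within the scatter) and with a 1.0-fold higher number from compound 1 to compound 4 (0.02 log units; within the scatter). The earlier compounds shown here showed only thiophen-2-yl, which separated from 4-bromophenyl with a 2.1-fold higher number from compound 1 to compound 3 (0.32 log units; beyond the scatter), whereas furan-2-yl shows that a five-membered ring at this position can match 4-bromophenyl in this assay.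

From the compounds shown here alone, whether a plain phenyl or a pyridin-2-yl ring at the same position would read alike remains open. Nothing available explains why these groups give such similar numbers.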